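The source may report more compounds than this note shows. Statements on the series, on what has been measured and on what is new or still open speak of the compounds shown alone.

For the measured compounds named here, compound 2, `NC(=O)c1c(NC(=O)c2ccccc2Cl)sc2c1CCN(Cc1ccccc1Cl)C2`, is one of two compounds measured in a functional assay on HL-60 cells (Homo sapiens) for antiproliferative activity, with a stated time of 24 h (a higher number here means a weaker inhibitor, a lower number a stronger inhibitor), where compound 2 gives 2900 nM, the only value reported as a number. Compound 1, `Cc1ccccc1CN1CCc2c(sc(NC(=O)c3ccccc3Cl)c2C(N)=O)C1`, differs from it by a methyl in place of the chloro on an aromatic carbon, and for compound 1 this assay reports only the limit > 50000 nM (the limit of > 50000 nM in this assay, at which 1 of the 2 values shown sits). That gives an at least 17-fold lower number from compound 1 to compound 2 (1.23 log units; beyond the scatter), so the chloro on that ring matters for potency. Compound 3, `NC(=O)c1c(NC(=O)c2ccccc2Cl)sc2c1CCN(C(=S)Nc1cccnc1)C2`, removes that ring altogether: a group of 9 heavy atoms (6 carbon, 2 nitrogen, 1 sulfur; one six-membered aromatic ring with 1 hetero atom) in place of a group of 8 heavy atoms (7 carbon, 1 chlorine; one six-membered aromatic ring of carbon only), on an amine nitrogen in a ring. Going by the values given here, no measured step covers this kind of exchange; the one known step only shows that the group being replaced is sensitive to small changes. Compound 3 is therefore estimated at 8000 nM, likely between 1500 nM and 50000 nM, and the step from compound 2 is expected to be a 2.8-fold higher number from compound 2 to compound 3 (0.44 log units; beyond the scatter), with a real chance the assay reports only a limit.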

Compound 3, half-maximal inhibitory concentration: 33900 nM
Beside the measured number, compound 3's estimate is 4.2-fold (0.63 log units) below it, and the stated range covers the measured number.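

Exchanging the 2-chlorobenzyl on the amine nitrogen in the ring for the new group has a large cost in this assay: a 12-fold higher number from compound 2 to compound 3 (1.07 log units; beyond the scatter). So this position is sensitive not only to a small swap on the aromatic ring but also to a change of the whole group, and the entering group does not keep the potency of compound 2. The comparison with the third compound gives an at least 1.4-fold lower number from compound 1 to compound 3 (0.16 log units; that floor lies within the scatter), which does not clearly separate the two, and compound 1 remains a limit of the assay: the limit of > 50000 nM in this assay, at which 1 of the 3 values shown sits.

The exchange changes the aromatic ring, the link to the nitrogen and the count of hydrogen-bond donors together, so the compounds shown cannot say which of these matters. An unsubstituted benzyl, or a carbonyl in place of the sulfur, would help to pull these apart.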